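A few compounds are considered here, and "the series" means these few. Any claim that something is new, unique, unknown or untested is made for them only; others in the source may bear on it.

In a functional assay on A549 cells (Homo sapiens) for antiproliferative activity, read by MTT assay, with a stated time of 72 h (on this read-out lower numbers stand for stronger inhibition and higher numbers for weaker inhibition), three compounds have been measured:

- compound 1 `COc1ccc(-c2ncnn2-c2cc(OC)c(OC)c(OC)c2)cc1`: 520 nM
- compound 2 `COc1cccc(-c2ncnn2-c2cc(OC)c(OC)c(OC)c2)c1`: > 10000 nM, a limit
- compound 3 `COc1cc(-c2ncnn2-c2ccc([N+](=O)[O-])cc2)cc(OC)c1OC`: > 10000 nM, a limit

Compound 1 is the only one of the three with an actual number, while the other two stand at the limit of > 10000 nM in this assay, at which 2 of the 3 values shown sit. Compound 4 `CCOc1ccc(-c2ncnn2-c2cc(OC)c(OC)c(OC)c2)cc1` has not yet been measured. It differs from compound 1 in one place, methoxy to ethoxy: methyl in place of hydrogen on a saturated chain carbon bound to an oxygen on an aromatic ring.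

Going by the values given here, only one measured step touches this methoxyphenyl group, an at least 19-fold higher number from compound 1 to compound 2 (1.28 log units; beyond the scatter). That large step shows that this assay can respond strongly to a change in this group. It is a different change, however, so it does not set the size of this one. Compound 4 keeps the 4-position of the methoxy-bearing group's oxygen substituent as in compound 1, so a small to moderate move towards weaker inhibition is expected, with a real risk of a larger loss. The expected change is a 1.5-fold higher number from compound 1 to compound 4 (0.19 log units; within the scatter). For compound 4 the estimated value is 800 nM, with an expected range of 150 nM to 4000 nM.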

Compound 4, half-maximal inhibitory concentration: 100 nM
Estimate against measurement, compound 4: 8.0-fold (0.90 log units) above; the whole stated range lies above it.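

In this assay there is a 5.2-fold lower number from compound 1 to compound 4 (0.72 log units; beyond the scatter) with the change from methoxy to ethoxy, so this group can also move the read-out towards stronger inhibition. Going by these compounds alone, the one earlier step on this group, an at least 19-fold higher number from compound 1 to compound 2 (1.28 log units; beyond the scatter) with 3-methoxyphenyl in place of 4-methoxyphenyl, went towards weaker inhibition and ended at a limit of the assay. Compound 4 now shows that the saturated chain carbon bound to the oxygen on the aromatic ring accepts a methyl in place of hydrogen and gains from it, though nothing shown here explains this gain.

Going by these compounds, whether the gain continues with a longer chain such as propoxy, or survives a branched isopropoxy, remains open. Also open, on these data alone, is whether an amine at the end of this chain would keep the inhibition seen with compound 4.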